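This account rests on a few compounds, and the source may have more. Where it says the series, first, only, none or still open, it means among the compounds named here.

Compound 1, `CC(C(=O)NCc1ccc(C(F)(F)F)cc1N1CCC(Cc2ccccc2)CC1)c1ccc(NS(C)(=O)=O)c(F)c1`, gives 1.4 nM in an assay on CHO cells for antagonist activity at transient receptor potential cation channel subfamily V member 1 (Homo sapiens), read by FLIPR; on this read-out lower numbers stand for stronger inhibition and higher numbers for weaker inhibition.
Compound 2, `CCCCCCOc1cc(C(C)(F)F)ccc1CNC(=O)C(C)c1ccc(NS(C)(=O)=O)c(F)c1`, gives 0.8 nM in this assay.
Compound 3, `CC(C)COc1cc(C(F)(F)F)ccc1CNC(=O)C(C)c1ccc(NS(C)(=O)=O)c(F)c1`, gives 0.8 nM in this assay.

Compound 3 stands level with compound 2 at the digits shown, and its gap to compound 1 lies within the usual scatter of repeated measurements. No pair among these three compounds is separated by more than the scatter, so the three numbers cannot be ranked against one another; all that can be said is that the three compounds, which differ from one another only in the group attached to the shared core, sit together at the potent end of this assay.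

Compound 4, `CC(C(=O)NCc1ccc(C(F)(F)F)cc1-c1cccc(Cl)c1)c1ccc(NS(C)(=O)=O)c(F)c1`, has not yet been measured in this assay. It differs from compound 3 in a single place: 3-chlorophenyl in place of isobutoxy on an aromatic carbon. Since the three measured compounds tolerate quite different groups at this part of the core without a change beyond the scatter, the step from compound 3 to compound 4 is expected to be small, a 2.5-fold higher number from compound 3 to compound 4 (0.40 log units; beyond the scatter), with at most a modest drift toward a weaker number. Compound 4 is therefore estimated at 2 nM in this assay, with a likely range from 0.5 nM to 8 nM.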

Compound 4, inhibition constant: 1 nM
For compound 4 the middle estimate is 2.0-fold (0.30 log units) above the measured one; measured number inside the range.
By their numbers in this assay, from the lowest: compounds 2, 3, 4 and 1 (each within the scatter of the next).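

In this assay, for the compounds shown here, the exchange of isobutoxy for 3-chlorophenyl gives a 1.3-fold higher number from compound 3 to compound 4 (0.10 log units; within the scatter) and is the first comparison here between two compounds that differ in one place. On this aromatic carbon, ortho to a large group and meta to a trifluoromethyl group, an open chain with one hydrogen-bond acceptor and an aromatic ring with none can therefore replace each other without a change beyond the scatter, so for this pair neither the oxygen nor the open chain of isobutoxy is needed to hold the number in this range. No evidence is available that would explain this tolerance.

On these data alone, whether a carboxylic acid or a primary amine on this same carbon would keep the number in this range remains open. Also open, as far as these compounds go, is what the chlorine of compound 4 contributes, a question that a plain phenyl group or a 4-chlorophenyl group at this position would address.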